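The source may report more compounds than this note shows. Statements on the series, on what has been measured and on what is new or still open speak of the compounds shown alone.

Measured so far:

Compound 1 `C=C1C[C@]23C[C@@]1(O)CC[C@@H]2c1cccc(C)c1[C@@H]3Cn1cc(-c2ccc(Br)cc2)nn1` – in a functional assay on SW480 cells (Homo sapiens) for cytotoxicity, read by MTT assay, with a stated time of 4 days (on this read-out lower numbers stand for stronger inhibition and higher numbers for weaker inhibition), compound 1 gives > 20000 nM, a limit of the assay.
Compound 2 `C=C1C[C@]23C[C@@]1(O)CC[C@H]2c1cc(Br)c(O)c(C)c1[C@@H]3Cn1cc(-c2ccc(C)cc2)nn1` – compound 2 gives > 20000 nM, likewise a limit.
Compound 3 `Cc1ccc(S(=O)(=O)Oc2ccc3c(c2C)[C@H](Cn2cc(-c4ccc(C(F)(F)F)cc4)nn2)[C@@]24CC(=O)[C@@](C)(CC[C@@H]32)C4)cc1` – compound 3 gives > 20000 nM, again a limit.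

Compound 1 therefore stands at the limit of > 20000 nM in this assay, at which 3 of the 3 values shown sit. For the measured compounds named here, no number has been reached for any member of the series so far, and no step between measured compounds is available, so nothing can be said about how the triazole substituent moves the read-out.

Compound 4 `C=C1C[C@]23C[C@@]1(O)CC[C@@H]2c1cccc(C)c1[C@@H]3Cn1cc(-c2ccc(OC)cc2)nn1` is the next member. It differs from compound 1 as follows: methoxy in place of bromo on an aromatic carbon.

With every measured value sitting at the limit, compound 4 is expected to stay at or near that limit, and the estimated step that the limit leaves unreadable from compound 1 to compound 4 is none beyond the scatter, in either direction. On that basis compound 4 is estimated at 25000 nM, with a range from 8000 nM to 80000 nM, the most likely outcome being that this assay again reports only a limit.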

Compound 4, half-maximal inhibitory concentration: > 20000 nM
Compound 4: a limit, no number; the forecaster's own chance of this, stated with the estimate: 70%; the middle value lies beyond the limit too.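

Compound 4 gives > 20000 nM in this assay, which is a limit and not a number. For the compounds shown here, compound 1 also sits at a limit, so no step from bromo to methoxy can be read between compound 1 and compound 4. The compounds shown leave open which structural change, if any, would yield a number rather than a limit.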